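This account rests on a few compounds, and the source may have more. Where it says the series, first, only, none or still open, it means among the compounds named here.

Measured in an ADME assay on CEM174 cells (Homo sapiens) for cytotoxicity; on this read-out lower numbers stand for higher toxicity in this test and higher numbers for lower toxicity in this test:

compound 1 `CCN(CC)CC[n+]1c(SCC(=O)NCCN)[nH]c2c(C)nc(N(CC)CC)nc21` gave 52.2 uM.
compound 2 `CCN(CC)CC[n+]1c(SCC(=O)NCCCN)[nH]c2c(C)nc(N(CC)CC)nc21` reached only a limit of this test, > 100 uM.
compound 3 `CCN(CC)c1nc(C)c2[nH]c(SCC(=O)NCCN)[n+](CCCN(C)C)c2n1` likewise reached only a limit of this test, > 100 uM.

Compounds 1 and 2 share one core and differ by aminomethyl in place of amino on a saturated chain carbon, two bonds along the chain from an amide-type nitrogen; that change gave an at least 1.9-fold higher number from compound 1 to compound 2 (0.28 log units; that floor lies within the scatter). Compounds 1 and 3 differ in their cores by (dimethylamino)methyl in place of diethylamino on a saturated chain carbon, two bonds along the chain from an aromatic nitrogen, a step that gave an at least 1.9-fold higher number from compound 1 to compound 3 (0.28 log units; that floor lies within the scatter). Compound 4 `CCN(CC)c1nc(C)c2[nH]c(SCC(=O)NCCCN)[n+](CCCN(C)C)c2n1` has not yet been measured in this assay. It differs from compound 3 by aminomethyl in place of amino on a saturated chain carbon, two bonds along the chain from an amide-type nitrogen, which is the same change as that from compound 1 to compound 2, made at the same place. Compound 4 is expected to give a step that the limit leaves unreadable from compound 3 to compound 4 from compound 3, resting on the step of an at least 1.9-fold higher number from compound 1 to compound 2 (0.28 log units; that floor lies within the scatter) and on the fact that (the limit of > 100 uM in this assay, at which 2 of the 3 values shown sit). Because the limit of > 100 uM in this assay, at which 2 of the 3 values shown sit, it is likely that compound 4 too will be reported only as a limit. Compound 4 is therefore estimated at 150 uM, with a range from 70 uM to 300 uM.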

Compound 4, half-maximal toxic concentration: > 100 uM
Compound 4: no number, only a limit; the forecaster's own chance of this, stated with the estimate: 85%; the middle value is on the limit's open side.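

In this assay compound 4 reached only a limit, > 100 uM. Among the compounds shown here, compound 2 and compound 3 also stand at a limit, so no step from either to compound 4 can be read: the limit of > 100 uM in this assay, at which 3 of the 4 values shown sit. The compounds shown leave open how far compound 2, compound 3 and compound 4 lie past that limit, and so whether they differ at all.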